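The source may report more compounds than this note shows. Statements on the series, on what has been measured and on what is new or still open speak of the compounds shown alone.

Measured so far in a functional assay on SW-620 cells (Homo sapiens) for inhibition, read by MTT assay, with a stated time of 72 h; on this read-out lower numbers stand for stronger inhibition and higher numbers for weaker inhibition:
Compound 1 `COc1ccc(CCCNCc2c(OC)cc(Oc3ccc(Nc4ccccc4)cc3)cc2OC)cc1` gives 14600 nM.
Compound 2 `COc1cc(Oc2cccc(Nc3ccccc3)c2)cc(OC)c1CNCc1ccc(F)cc1` gives 6770 nM.
Compound 3 `COc1cc(Oc2cccc(Nc3ccccc3)c2)cc(OC)c1CNCc1ccc(Cl)cc1` gives 6340 nM.

Compound 3 shows the lowest number of the three in this assay. Its gap to compound 2 is the step of a 1.1-fold lower number from compound 2 to compound 3 (0.03 log units; within the scatter), so the two cannot be told apart. Compound 1 shows the highest number, and its gap to compound 3 lies beyond the scatter, but compound 1 differs from compound 3 in more than one place, so only the two values themselves can be set side by side.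

Compound 4 `COc1cc(Oc2cccc(Nc3ccccc3)c2)cc(OC)c1CNC1CC1` is the next step: cyclopropyl in place of 4-chlorobenzyl on an amine nitrogen. Going by the values given here, no measured step bears on this change. Among the compounds with values here, the single step in hand, a 1.1-fold lower number from compound 2 to compound 3 (0.03 log units; within the scatter), swaps chloro for fluoro on an aromatic carbon and says nothing about replacing 4-chlorobenzyl with cyclopropyl. Compound 1 cannot serve as a guide either. It differs from compound 3 in more than one place. With nothing to anchor it, the move from the group of eight heavy atoms to the group of three is expected to raise the number; as an estimate, the step of a 2.5-fold higher number from compound 3 to compound 4 (0.40 log units; beyond the scatter) is taken to lie beyond the scatter, though with wide uncertainty. Compound 4 is therefore expected near 16000 nM, within 5000 nM to 45000 nM.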

Compound 4, half-maximal inhibitory concentration: > 20000 nM
Compound 4 was reported as a limit; the forecaster's own chance of this, stated with the estimate: 15%; middle value at least 1.2-fold (0.09 log units) away from the limit.
By their numbers in this assay, from the lowest: compounds 3 and 2 (each within the scatter of the next); then compound 1. At a limit, above all of these: compound 4.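

Compound 4 is reported only as a limit in this assay: the limit of > 20000 nM in this assay, at which 1 of the 4 values shown sits.

Read against the two benzyl compounds, the change at the amine nitrogen gives an at least 3.1-fold higher number from compound 3 to compound 4 (0.49 log units; beyond the scatter) and an at least 2.9-fold higher number from compound 2 to compound 4 (0.47 log units; beyond the scatter), and both are lower bounds on the true size of the step. The earlier halogen swap, a 1.1-fold lower number from compound 2 to compound 3 (0.03 log units; within the scatter), left open whether the group on this nitrogen affects the read-out at all, whereas these steps show that it does: with the rest of the structure unchanged, both 4-chlorobenzyl and 4-fluorobenzyl give lower numbers than cyclopropyl. The result therefore favours keeping a substituted benzyl at this position over the cyclopropyl, though only these three groups on this core can be compared.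

The change removes the six-membered aromatic ring and also shortens the group in heavy atoms, and the compounds shown do not separate these two differences. An unsubstituted benzyl, a phenethyl or an open-chain alkyl such as isopropyl on the same nitrogen would bear on that question, as would a methoxy in place of the halogen on the benzyl.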